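This account rests on a few compounds, and the source may have more. Where it says the series, first, only, none or still open, it means among the compounds named here.

Compound 1 `N[C@]1(C(=O)O)[C@H]2[C@@H](C[C@H]1OCc1ccccc1Cl)[C@]2(F)C(=O)O`: 4.99 nM
Compound 2 `N[C@]1(C(=O)O)[C@H]2[C@@H](C[C@H]1OCc1ccccc1-c1ccccc1)[C@]2(F)C(=O)O`: 4.07 nM
Compound 3 `N[C@]1(C(=O)O)[C@H]2[C@@H](C[C@H]1OCc1cccc([N+](=O)[O-])c1)[C@]2(F)C(=O)O`: 7.87 nM

Three compounds on a shared core were measured in an assay on CHO cells for binding affinity to metabotropic glutamate receptor 2 (Rattus norvegicus); a higher number here means a weaker inhibitor, a lower number a stronger inhibitor. Compound 1 gives 4.99 nM and stands second highest of the three numbers; compound 2 lies nearest to it, and compound 3 furthest, yet both gaps are within the scatter, so no order among the three can be claimed.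

Compound 4 `N[C@]1(C(=O)O)[C@H]2[C@@H](C[C@H]1OCc1cccc(F)c1F)[C@]2(F)C(=O)O` differs from compound 1 in one place: 2,3-difluorophenyl in place of 2-chlorophenyl on a saturated chain carbon bound to an oxygen on a saturated carbon. Among the measured compounds shown here, the only measured step that bears on a change of the benzyl ring is a 1.2-fold lower number from compound 1 to compound 2 (0.09 log units; within the scatter), which stayed within the scatter. The pair of compound 1 and compound 3 shows two values that also lie within the scatter of each other. Every variation of this ring seen so far has left this assay essentially unchanged, so for compound 4 no step beyond the scatter is expected in either direction: the expected change is a 1.1-fold higher number from compound 1 to compound 4 (0.04 log units; within the scatter). Compound 4 is therefore estimated at 5.5 nM, with a range from 2.5 nM to 12 nM.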

Compound 4, inhibition constant: 4.25 nM
Estimate against measurement, compound 4: 1.3-fold (0.11 log units) above, within the range that was stated.
By their numbers in this assay, from the lowest: compounds 2, 4, 1 and 3 (each within the scatter of the next).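

In this assay, 2,3-difluorophenyl in place of 2-chlorophenyl gave a 1.2-fold lower number from compound 1 to compound 4 (0.07 log units; within the scatter) on a saturated chain carbon bound to an oxygen on a saturated carbon. Compound 4 thus adds a second kind of change to the one already seen, a 1.2-fold lower number from compound 1 to compound 2 (0.09 log units; within the scatter): here chlorine leaves, two fluorines enter, and the aromatic ring itself stays, yet both steps remain within the scatter and neither goes against the other. No data at hand bear on why this place responds so little to these changes.

The compounds shown leave open whether the number would stay as flat with an amine or a carboxylic acid on the aromatic ring. They also leave open whether a longer saturated chain in place of 2-chlorophenyl would produce a step beyond the scatter.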